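This account rests on a few compounds, and the source may have more. Where it says the series, first, only, none or still open, it means among the compounds named here.

Working notes on the series.

Compound 1 `Cc1nnc(-c2cccc(-c3ccc(C(=O)N(Cc4cccc(OCCCCCC(=O)O)c4)C(C)C)cc3)c2)o1` sits at the ceiling of an ADME assay on BJ cells (Homo sapiens) for cytotoxicity, read by CellTiter-Glo and resazurin assay, with a stated time of 72 h; on this read-out lower numbers stand for an effect already at smaller amounts and higher numbers for an effect only at larger amounts of compound. In this assay compound 1 gives > 26000 nM, which is a limit of the assay and not a number. Compound 2 `CC(C)N(Cc1cccc(OCCCCCC(=O)O)c1)C(=O)c1ccc(-c2ccc3cc[nH]c3c2)cc1` carries 1H-indol-6-yl in place of 3-(5-methyl-1,3,4-oxadiazol-2-yl)phenyl on an aromatic carbon. In this assay compound 2 gives > 26000 nM, again a limit of the assay rather than a number. The step that the two limits leave unreadable from compound 1 to compound 2 therefore cannot be sized; all that can be said is that both compounds are at the limit of > 26000 nM in this assay, at which 2 of the 2 values shown sit.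

Compound 3 `COc1cc(OC)cc(-c2ccc(C(=O)N(Cc3cccc(OCCCCCC(=O)O)c3)C(C)C)cc2)c1` is the next point. The change is 3,5-dimethoxyphenyl in place of 1H-indol-6-yl on an aromatic carbon. Among the measured compounds shown here, no measured step bears on this exchange in a readable way, and the two limits give no direction to work from. With both neighbours at the ceiling, compound 3 is expected to stay there as well, so the step that the limit leaves unreadable from compound 2 to compound 3 is estimated as none beyond the scatter. For compound 3 the estimate in this assay is 30000 nM, within the range 15000 nM to 100000 nM, most likely reported again only as a limit.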

Compound 3, half-maximal effective concentration: > 26000 nM
Compound 3 was reported as a limit; the forecaster's own chance of this, stated with the estimate: 80%; the middle value lies beyond the limit too.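

In this assay compound 3 gives > 26000 nM as a limit of the assay and not a number. The steps among compound 1, compound 2 and compound 3 therefore cannot be read, and all three stand at the same ceiling: the limit of > 26000 nM in this assay, at which 3 of the 3 values shown sit.

The compounds shown leave open which exchange on the aromatic carbon, if any, would give a readable number in this assay at all.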